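Chloro in place of methyl on compound 1

A few compounds are considered here, and "the series" means these few. Any claim that something is new, unique, unknown or untested is made for them only; others in the source may bear on it.

In an ADME assay on the whole organism (Canis lupus familiaris) for pharmacokinetics (a lower number here means slower removal, a higher number faster removal of the compound), compound 1 (`Cc1cc(C(F)(F)F)ccc1-c1cc2cnn([C@@H](CC(C)C)c3ccc(C(=O)NCCC(=O)O)cc3)c2cc1C`) gives 0.21 mL/min/kg and compound 2 (`Cc1cc(C(F)(F)F)ccc1-c1cc2cn([C@@H](CC(C)C)c3ccc(C(=O)NCCC(=O)O)cc3)nc2cc1C`) gives 0.19 mL/min/kg so the two numbers lie within the scatter of each other. The unmeasured compound 3 (`Cc1cc2c(cnn2[C@@H](CC(C)C)c2ccc(C(=O)NCCC(=O)O)cc2)cc1-c1ccc(C(F)(F)F)cc1Cl`) keeps the core of compound 1 and differs in one place, as chloro in place of methyl on an aromatic carbon shows, with chloro in place of methyl on an aromatic carbon. For the measured compounds named here, no measured pair shows this change. The expected step is a 1.2-fold higher number from compound 1 to compound 3 (0.08 log units; within the scatter) and it is expected to stay within the scatter. For compound 3 the estimate is 0.25 mL/min/kg with an expected range from 0.1 mL/min/kg to 0.6 mL/min/kg in this assay once measured.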

Compound 3, clearance: 0.21 mL/min/kg
The estimate for compound 3 lay 1.2-fold (0.08 log units) above the measured number; the range from low to high includes it.
By their numbers in this assay, from the lowest: compounds 2, 1 and 3 (each within the scatter of the next).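

In this assay, for the compounds shown here, replacing the 2-methyl-4-(trifluoromethyl)phenyl group with 2-chloro-4-(trifluoromethyl)phenyl gives no change at the digits printed from compound 1 to compound 3 (within the scatter) and so provides the first reading of a change at this position. On the core of compound 1, this aromatic carbon, ortho to a large group and meta to a trifluoromethyl group, carries either methyl or chloro with no step beyond the scatter. No measurement at hand gives a reason for this result. Still open, as far as these compounds go, is whether a nitrile or a methoxy group at this position would leave the number within the scatter as well. Also open, from the compounds shown here alone, is whether chloro would do the same on compound 2.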